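This account rests on a few compounds, and the source may have more. Where it says the series, first, only, none or still open, it means among the compounds named here.

In a functional assay on HEK293 cells with D(4) dopamine receptor (Homo sapiens) as the target, read by FLIPR (a higher number here means a larger maximal response, a lower number a smaller maximal response), compound 1 `O/N=C(\CCN1CCN(c2ccccn2)CC1)c1ccccc1` gives 70%. Compound 2 `CCCO/N=C(\CCN1CCN(c2ccccn2)CC1)c1ccccc1` gives 64% in this assay, the lower of the two numbers, though its gap to compound 1 lies within the scatter; that step, a number 6 percentage points lower from compound 1 to compound 2 (within the scatter), was propyl in place of hydrogen on an oxygen. Compound 3 `CC(C)O/N=C(\CCN1CCN(c2ccccn2)CC1)c1ccccc1` differs from compound 2 by isopropyl in place of propyl on an oxygen. Within the data shown here, the only measured step touches the same oxygen and stayed within the scatter, so no movement beyond the scatter is expected in this assay; the expected step is a number 1 percentage points lower from compound 2 to compound 3 (within the scatter). Compound 3 is therefore estimated at 63%, with a range from 45% to 80%.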

Compound 3, largest response reached (reported as efficacy), in percent of the reference or control that the assay uses: 83%
For compound 3 the middle estimate is 20 percentage points below the measured one; the whole stated range lies below it.
By their numbers in this assay, from the lowest: compounds 2 and 1 (each within the scatter of the next); then compound 3.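

At this oxygen, whose other neighbour is the double-bonded nitrogen, the arrangement of the chain alone changed the outcome in this assay: propoxy to isopropoxy, with the same atoms joined differently, gave a number 19 percentage points higher from compound 2 to compound 3 (beyond the scatter). Isopropyl also separated from the unsubstituted oxygen, with a number 13 percentage points higher from compound 1 to compound 3 (beyond the scatter), which propyl had not done. Nothing available here accounts for this difference between the two chains. From the compounds shown here alone, whether a more branched tert-butyl or a cyclopropyl group on the same oxygen would follow isopropyl or propyl remains open.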